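This account rests on a few compounds, and the source may have more. Where it says the series, first, only, none or still open, it means among the compounds named here.

Measured compounds in the series:
- compound 1 `CNC(=O)c1cc(Oc2ccc(NC(=O)c3nn(-c4ccccc4C(F)(F)F)c(=O)cc3C)cc2F)ccn1` — 35700 nM
- compound 2 `CNC(=O)c1cc(Oc2ccc(NC(=O)c3nn(-c4cccc(F)c4)c(=O)cc3C)cc2F)ccn1` — 6410 nM
- compound 3 `Cc1cc(=O)n(-c2ccc(Br)cc2F)nc1C(=O)Nc1ccc(Oc2ncnc3ccsc23)cc1` — 9360 nM

In a functional assay on MCF7 cells (Homo sapiens) for cytotoxicity, read by MTT assay, with a stated time of 72 h (on this read-out higher numbers stand for weaker inhibition and lower numbers for stronger inhibition), compound 3 stands second highest of the three numbers. Its nearest neighbour is compound 2, and the two values lie within the scatter of each other; compound 1 lies furthest away, its number being beyond the scatter above that of compound 3.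

Compound 4 `Cc1cc(=O)n(-c2ccc(F)c(F)c2)nc1C(=O)Nc1ccc(Oc2ncnc3ccsc23)cc1` is the next member to be measured. It differs from compound 3 in one place: 3,4-difluorophenyl in place of 4-bromo-2-fluorophenyl on an aromatic nitrogen.

Within the data shown here, only one measured step bears on this change, and only loosely. The step of a 5.6-fold lower number from compound 1 to compound 2 (0.75 log units; beyond the scatter) also exchanged the aryl group on the aromatic nitrogen, but on a different core and with a different pair of groups, so it is at best a pointer to the size of effect such a swap can have in this assay. Among the measured compounds shown here, no step within the core of compound 3 is available, and no step shows a bromine-to-fluorine exchange on the aryl group.

On that basis a small step is expected, toward a lower number, of size a 1.3-fold lower number from compound 3 to compound 4 (0.13 log units; within the scatter), with a wide range. Compound 4 is thus estimated at 7000 nM, between 2500 nM and 20000 nM.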

Compound 4, half-maximal inhibitory concentration: 5550 nM
Compound 4: the middle estimate sits 1.3-fold (0.10 log units) above what was measured, and the stated range covers the measured number.
By their numbers in this assay, from the lowest: compounds 4, 2 and 3 (each within the scatter of the next); then compound 1.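

In this assay, the exchange of 4-bromo-2-fluorophenyl for 3,4-difluorophenyl on the aromatic nitrogen gives a 1.7-fold lower number from compound 3 to compound 4 (0.23 log units; within the scatter), so compound 3 and compound 4 cannot be told apart on this read-out. Among these compounds, this is the first aryl exchange at this position read on the core of compound 3, and it shows that, on this core, the bromine can give way and the fluorine pattern can be rearranged without a step beyond the scatter, whereas the earlier exchange, a 5.6-fold lower number from compound 1 to compound 2 (0.75 log units; beyond the scatter), involved another pair of groups on another core and showed only that an aryl swap at this position can move the number. Nothing measured here accounts for the result, and no supporting data bear on it.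

The aryl groups shown carry only halogens or trifluoromethyl, so it remains open how this position responds to a phenyl group bearing an amine or a carboxylic acid, or to a longer alkyl chain in place of the aryl group. As far as these compounds go, it is equally open whether the exchange from compound 3 to compound 4 would give a similar step on the core of compound 1.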